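The source may report more compounds than this note shows. Statements on the series, on what has been measured and on what is new or still open speak of the compounds shown alone.

Compound 1 `COc1ccc(-c2cnc(NC(=O)CCc3ccccc3)n2C)cc1` carries an amide built on phenethyl. In a toxicity assay on THP-1 cells (Homo sapiens) for inhibition (on this read-out lower numbers stand for higher toxicity in this test and higher numbers for lower toxicity in this test), compound 1 gives only a limit, > 100000 nM, not a number. Compound 2 `Cc1ccccc1-c1cnc(NC(=O)c2ccc(F)cc2)n1C` belongs to the same series; in this assay compound 2 likewise gives only a limit, > 50000 nM. Both results are limits rather than measured values, the limit of > 100000 nM in this assay, at which 1 of the 2 values shown sits, and (the limit of > 50000 nM in this assay, at which 1 of the 2 values shown sits), so compound 1 stands at the top of what this test reports, showing no toxicity that the test could pin down. Compound 3 `COc1ccc(-c2cnc(NC(=O)C3CCCCC3)n2C)cc1` has not yet been measured. It differs from compound 1 in one place: cyclohexyl in place of phenethyl on a carbonyl carbon. Within the data shown here, no step between two measured compounds is available here to guide the size of this change. Because compound 1 gives only a limit (the limit of > 100000 nM in this assay, at which 1 of the 2 values shown sits), the step of a number no higher from compound 1 to compound 3 (the limit leaves the size open) is expected to be none beyond the scatter. Compound 3 is therefore estimated at 100000 nM, within 50000 nM to 300000 nM, and most likely reported again only as a limit.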

Compound 3, half-maximal cytotoxic concentration: > 100000 nM
Compound 3 gave a limit, no number; the forecaster's own chance of this, stated with the estimate: 80%; the middle value sits exactly at the limit.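

Compound 1 and compound 3 both give only a limit in this assay, so no step can be read for cyclohexyl in place of phenethyl: the limit of > 100000 nM in this assay, at which 2 of the 3 values shown sit.

The compounds shown leave open whether these two groups differ at all, and what actual toxic concentration any of these compounds has.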